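This account rests on a few compounds, and the source may have more. Where it says the series, first, only, none or still open, it means among the compounds named here.

Measured so far in an assay on isolated protein for inhibition of Amine oxidase [flavin-containing] B (Homo sapiens); a lower number here means a stronger inhibitor, a higher number a weaker inhibitor:
compound 1 `C#CCNC1CCc2c(OCc3cccc(C(F)(F)F)c3)cccc21` gives 6410 nM
compound 2 `C#CCNC1CCc2c(SCCc3ccc(C)cc3)cccc21` gives 25800 nM
compound 3 `C#CCNC1CCc2c(SCc3ccc(C)cc3)cccc21` gives 1560 nM

Compound 2 shows the highest number of the three; its gaps to compound 1 and to compound 3 both lie beyond the scatter, so among these three it is the weakest inhibitor in this assay. Compound 4 `C#CCNC1CCc2c(SCCc3cccc(OC)c3)cccc21` is not yet measured. It differs from compound 2 in one respect: 3-methoxyphenyl in place of 4-methylphenyl on a saturated chain carbon, two bonds along the chain from a sulfur. Among the measured compounds shown here, no pair of measured compounds isolates a change of this kind, and compound 1 and compound 3 each differ from compound 2 in more than one place, so their numbers offer no direct guide to it. The expectation for compound 4 in this assay is therefore a step of modest size, in no firm direction, most likely none beyond the scatter, a 1.3-fold lower number from compound 2 to compound 4 (0.11 log units; within the scatter). Compound 4 is estimated at 20000 nM, with a range from 6000 nM to 60000 nM.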

Compound 4, half-maximal inhibitory concentration: 28700 nM
The estimate for compound 4 lay 1.4-fold (0.16 log units) below the measured number; low and high end bracket the measured number.
By their numbers in this assay, from the lowest: compound 3; then compound 1; then compounds 2 and 4 (each within the scatter of the next).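

In this assay, putting 3-methoxyphenyl in place of 4-methylphenyl on a saturated chain carbon, two bonds along the chain from a sulfur, gives a 1.1-fold higher number from compound 2 to compound 4 (0.05 log units; within the scatter) and so leaves the number unmoved within the scatter. The exchange alters both the ring substituent and its location and adds a hydrogen-bond acceptor, yet this single pair shows no measurable consequence at this position. No outside data on this change are available to interpret the result.

Going by these compounds, it remains open whether any replacement at this position can move the number beyond the scatter, for example an amine or a carboxylic acid in place of the substituted phenyl ring. On these data alone, it is also open whether 3-methoxyphenyl would give the same result on a longer chain.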